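A Furan in Place of the Methoxyphenyl Group

A few compounds are considered here, and "the series" means these few. Any claim that something is new, unique, unknown or untested is made for them only; others in the source may bear on it.

Compound 1, `COc1ccccc1C1C(C#N)=C(N)N(c2ccc(S(N)(=O)=O)cc2)C2=C1CCCC2`, gives 100% in a functional assay on Ehrlich cells (Mus musculus) for cytotoxicity, read by trypan blue exclusion, with a stated time of 2 h, tested at 100 ug/mL; a higher number here means a stronger effect of the compound at the concentration tested, a lower number a weaker effect.
Compound 2, `COc1ccc2ccccc2c1C1C(C#N)=C(N)N(c2ccc(S(N)(=O)=O)cc2)C2=C1CCCC2`, gives 50% in this assay.
Compound 3, `COc1ccc(C2C(C#N)=C(N)N(c3ccc(S(N)(=O)=O)cc3)C3=C2CCCC3)c2ccccc12`, gives 20% in this assay.

Three compounds share one core and differ only in the aromatic group on a saturated ring carbon. Compound 1 stands highest of the three numbers in this assay. Its nearest neighbour is compound 2, which lies a good way lower, beyond the usual scatter, and compound 3 lies lower still, also beyond the scatter. So the group on that carbon clearly matters for the read-out, although with only three compounds no rule about which groups help can be drawn.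

Compound 4, `Cc1ccc(C2C(C#N)=C(N)N(c3ccc(S(N)(=O)=O)cc3)C3=C2CCCC3)o1`, has not yet been measured. It differs from compound 1 as follows: 5-methylfuran-2-yl in place of 2-methoxyphenyl on a saturated ring carbon. For the measured compounds named here, no measured pair shows this particular change, so its effect is unknown. Since both alternatives measured so far reduce the read-out relative to compound 1, a moderate drop is expected, with a wide range, and the step of a number 40 percentage points lower from compound 1 to compound 4 (beyond the scatter) is my estimate. For compound 4 an activity of 60% is expected, between 20% and 100%.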

Compound 4, a percentage reported as activity, at one concentration (the size of the read-out at that concentration, not a potency): 30%
Estimate against measurement, compound 4: 30 percentage points above; measured number inside the range.
By their numbers in this assay, from the lowest: compounds 3 and 4 (each within the scatter of the next); then compound 2; then compound 1.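

In this assay, putting 5-methylfuran-2-yl in place of 2-methoxyphenyl on a saturated ring carbon gives a number 70 percentage points lower from compound 1 to compound 4 (beyond the scatter), so a single swap at this carbon can remove most of the read-out. The earlier compounds shown here showed a loss only with the larger aromatic groups of compound 2 and compound 3, whereas this entering group has fewer heavy atoms than 2-methoxyphenyl and the read-out still falls, leaving compound 3 and compound 4 within the scatter of each other even though their groups look very different. So among these four compounds, group size alone does not sort the numbers, and compound 1 stays clearly highest, but nothing shown here explains why the read-out falls with this change.

On these data alone, it remains open how much of the step belongs to the five-membered ring and how much to its methyl, a question that a plain furan-2-yl group at the same carbon would help to separate. As far as these compounds go, the part played by the methoxy group of compound 1 is also open, and a plain phenyl or a 2-hydroxyphenyl group there would test it directly.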